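The source may report more compounds than this note shows. Statements on the series, on what has been measured and on what is new or still open speak of the compounds shown alone.

Working notes on the series. In an ADME assay on MRC5 cells (Homo sapiens) for inhibition, with a stated time of 72 h (on this read-out lower numbers stand for an effect already at smaller amounts and higher numbers for an effect only at larger amounts of compound), compound 1 `COc1cccc(OC)c1C(=O)Nc1c[nH]nc1C(=O)NC1CC2CCC1C2` gives only a limit of the assay, > 50000 nM. Compound 1 therefore stands at the limit of > 50000 nM in this assay, at which 1 of the 3 values shown sits. Compound 2 `CO[C@H]1CC[C@H](NC(=O)c2n[nH]cc2NC(=O)c2ccc(OC(F)F)cc2)CC1` gives 2500 nM in this assay. Compound 3 `CO[C@H]1CC[C@H](NC(=O)c2n[nH]cc2NC(=O)c2cnc3ccccn23)CC1` gives 5900 nM in this assay. No two of the measured compounds differ in a single place, so the numbers of compound 2 and compound 3 can only be read side by side. Compound 4 `COc1cccc(OC)c1C(=O)Nc1c[nH]nc1C(=O)NC1CCC(C)CC1` differs from compound 1 by a group of 7 heavy atoms (7 carbon; one six-membered non-aromatic ring of carbon only) in place of a group of 7 heavy atoms (7 carbon; 2 five-membered non-aromatic rings of carbon only), on an amide-type nitrogen. With compound 1 resting on a limit, the direction of any movement is hard to read; the expected step of a number no higher from compound 1 to compound 4 (the limit leaves the size open) is none beyond the scatter. Compound 4 is estimated at 50000 nM, with a range from 20000 nM to 100000 nM, and a fair chance that again only a limit is reported.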

Compound 4, half-maximal effective concentration: 45000 nM
Estimate against measurement, compound 4: 1.1-fold (0.05 log units) above, within the range that was stated.
By their numbers in this assay, from the lowest: compound 2; then compound 3; then compound 4. At a limit, above all of these: compound 1.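

Placing 4-methylcyclohexyl on the amide-type nitrogen, in place of the group with two five-membered rings, gives in this assay an at least 1.1-fold lower number from compound 1 to compound 4 (0.04 log units; that floor lies within the scatter). This change at the position yields a measured number for compound 4, but no shift beyond the scatter can be claimed from it. The true size of the step remains unknown, as the value for compound 1 is a limit of the assay: the limit of > 50000 nM in this assay, at which 1 of the 4 values shown sits.

Still open, going by these compounds, is how an amine or a carboxylic acid on the 4-methylcyclohexyl group would read in this assay. Also open, on these data alone, is whether this change would act alike on the cores of compound 2 and compound 3.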